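The source may report more compounds than this note shows. Statements on the series, on what has been measured and on what is new or still open speak of the compounds shown alone.

Measured so far in a functional assay on A549 cells (Homo sapiens) for cytotoxicity, read by XTT assay, with a stated time of 24 h; a higher number here means a weaker inhibitor, a lower number a stronger inhibitor:
Compound 1 `Cn1nnnc1SCC(=O)N/N=C/c1cccc(F)c1` gives 6320000 nM.
Compound 2 `Cn1nnnc1SCC(=O)N/N=C/c1cccc(Br)c1` gives 600000 nM.
Compound 3 `COc1cccc(/C=N/NC(=O)CSc2nnnn2C)c1` gives > 10000000 nM, which is a limit of the measurement and not a number.

Compound 3 therefore stands at the limit of > 10000000 nM in this assay, at which 1 of the 3 values shown sits. The measured steps that bear on it are an at least 1.5-fold higher number from compound 1 to compound 3 (0.19 log units; that floor lies within the scatter) and an at least 16-fold higher number from compound 2 to compound 3 (1.22 log units; beyond the scatter), both leading from a halogen to methoxy. Compound 4 `Cc1cccc(/C=N/NC(=O)CSc2nnnn2C)c1` differs from compound 3 by methyl in place of methoxy on an aromatic carbon. For the measured compounds named here, no measured step covers a methyl, so the expectation rests on the weak standing of compound 3 alone. Compound 4 is expected to give 8000000 nM, with a range from 2000000 nM to 30000000 nM, and may well again return only a limit. The expected step is an at least 1.2-fold lower number from compound 3 to compound 4 (0.09 log units; that floor lies within the scatter), small and within the scatter.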

Compound 4, half-maximal inhibitory concentration: 2000000 nM
For compound 4 the middle estimate is 4.0-fold (0.60 log units) above the measured one; the range from low to high includes it.
By their numbers in this assay, from the lowest: compound 2; then compound 4; then compound 1. At a limit, above all of these: compound 3.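

In this assay, methyl on this aromatic carbon gives a measurable value where methoxy did not, with an at least 5.0-fold lower number from compound 3 to compound 4 (0.69 log units; beyond the scatter). Compound 3 remains at a limit of the assay and not at a number: the limit of > 10000000 nM in this assay, at which 1 of the 4 values shown sits. Methyl also falls between the two halogens, with a 3.3-fold higher number from compound 2 to compound 4 (0.52 log units; beyond the scatter) and a 3.2-fold lower number from compound 1 to compound 4 (0.50 log units; beyond the scatter), so a small carbon group here need not leave the compound at the weak end of the series.

The compounds shown leave open where chloro, an amine or a carboxylic acid would fall in this order.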